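Swapping thiophen-3-yl for bromo on a shared core

This account rests on a few compounds, and the source may have more. Where it says the series, first, only, none or still open, it means among the compounds named here.

Of the compounds shown here, three have been measured in an ADME assay on HEL cells (Homo sapiens) for cytotoxicity, with a stated time of 3 days; a higher number here means that more compound is tolerated, a lower number that less compound is tolerated. Compound 1 `c1ccc(CCSCc2cnc3ccc(-c4ccccc4)cn23)cc1` gives 9.9 ug/mL, and compound 2 `Cc1cc(-c2cccc([N+](=O)[O-])c2)c2ncc(CSCCc3ccccc3)n2c1` gives 47 ug/mL. Compound 3 `Cc1cc(-c2ccsc2)cn2c(CSCCc3ccccc3)cnc12` reports only a limit, > 50 ug/mL, so its true value is not known as a number. For the measured compounds named here, it sits at the limit of > 50 ug/mL in this assay, at which 1 of the 3 values shown sits, the ceiling of this assay, and no step between measured compounds is available to calibrate the change that follows.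

Compound 4 `Cc1cc(Br)cn2c(CSCCc3ccccc3)cnc12` differs from compound 3 by one change: bromo in place of thiophen-3-yl on an aromatic carbon. Going by the values given here, with no measured step to draw on, the expected step in this assay from compound 3 to compound 4 is an at least 1.2-fold lower number from compound 3 to compound 4 (0.09 log units; that floor lies within the scatter), which is not expected to exceed the usual scatter. Compound 4 is therefore estimated at 40 ug/mL, in a range from 15 ug/mL to 80 ug/mL, with a fair chance that only a limit is reported.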

Compound 4, half-maximal cytotoxic concentration: 28 ug/mL
Compound 4: the middle estimate sits 1.4-fold (0.15 log units) above what was measured, and the stated range covers the measured number.
By their numbers in this assay, from the lowest: compound 1; then compounds 4 and 2 (each within the scatter of the next). At a limit, above all of these: compound 3.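

In this assay, bromo in place of thiophen-3-yl on this aromatic carbon gives an at least 1.7-fold lower number from compound 3 to compound 4 (0.25 log units; that floor lies within the scatter). With bromo at this position, compound 4 gives a measured number, 28 ug/mL, and so shows a cytotoxic concentration within the range of this read-out. Compound 3 has only a limit, so the step is only a floor: the limit of > 50 ug/mL in this assay, at which 1 of the 4 values shown sits.

On these data alone, the true size of the step remains open. So does how an amine or a methoxy group on this aromatic carbon would read in this assay.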